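The source may report more compounds than this note shows. Statements on the series, on what has been measured and on what is new or still open speak of the compounds shown alone.

Compound 1 `O=C1C(=Cc2ccc(O)cc2)C(=O)N(c2ccc(Cl)cc2)N1c1ccc(Cl)cc1`: 19500 nM
Compound 2 `COc1cccc(C=C2C(=O)N(c3ccc(Cl)cc3)N(c3ccc(Cl)cc3)C2=O)c1OC`: 29600 nM

In a functional assay on MGC-803 cells (Homo sapiens) for cytotoxicity, read by MTT assay, with a stated time of 72 h (on this read-out lower numbers stand for stronger inhibition and higher numbers for weaker inhibition), compound 2 gives 29600 nM and compound 1 gives 19500 nM, so the two lie within the usual scatter of each other. Compound 3 `O=C1C(=Cc2ccc(Cl)cc2Cl)C(=O)N(c2ccc(Cl)cc2)N1c1ccc(Cl)cc1` keeps the shared core of compound 2 and differs in one group, on a double-bonded chain carbon bound to a double-bonded ring carbon: 2,4-dichlorophenyl in place of 2,3-dimethoxyphenyl on a double-bonded chain carbon bound to a double-bonded ring carbon. In short, 2,4-dichlorophenyl takes the place of 2,3-dimethoxyphenyl. Among the measured compounds shown here, only one measured step bears on this change, a swap of groups at that same place, and it is small: a 1.5-fold higher number from compound 1 to compound 2 (0.18 log units; within the scatter). For the measured compounds named here, no chlorine-bearing group has yet been measured there, so the data point in no clear direction, and no step beyond the scatter is expected. The expected step is a 1.5-fold lower number from compound 2 to compound 3 (0.17 log units; within the scatter). For compound 3 the estimate is 20000 nM, with an expected range of 8000 nM to 50000 nM.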

Compound 3, half-maximal inhibitory concentration: > 128000 nM
Compound 3 gave a limit, no number; the forecaster's own chance of this, stated with the estimate: 10%; at least 6.4-fold (0.80 log units) between middle value and limit.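

In this assay compound 3 gives > 128000 nM, which is a limit of the assay and not a number. Even so, the swap to 2,4-dichlorophenyl yields an at least 4.3-fold higher number from compound 2 to compound 3 (0.63 log units; beyond the scatter), and the comparison with the 4-hydroxyphenyl compound yields an at least 6.5-fold higher number from compound 1 to compound 3 (0.81 log units; beyond the scatter). Among the compounds shown here, the earlier swap at this place stayed within the scatter, so these steps are the first sign that the group on this chain carbon can matter, with the 2,4-dichlorophenyl compound inhibiting more weakly than the other two.

The compounds shown leave open whether the loss follows from the chlorine atoms themselves or from where they sit on the ring. Also open, on these data alone, is whether a 4-chlorophenyl group, with a single chlorine, or a 4-aminophenyl group, carrying an amine, would stay close to compound 1 and compound 2.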